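A few compounds are considered here, and "the series" means these few. Any claim that something is new, unique, unknown or untested is made for them only; others in the source may bear on it.

Measured compounds and values in a functional assay on HL-60 cells (Homo sapiens) for cytotoxicity, read by WST assay, with a stated time of 48 h; a lower number here means that less compound is needed, a higher number that more compound is needed for the effect:

Compound 1 `O=C1OC[C@H](Cc2ccccc2)[C@H]1Cc1ccccc1O`: 83000 nM
Compound 2 `CCCCOc1ccccc1C[C@H]1C(=O)OC[C@@H]1Cc1ccccc1`: 20000 nM
Compound 3 `CCCCOc1cc(C[C@H]2C(=O)OC[C@@H]2Cc2ccccc2)ccc1O`: 35000 nM

Compound 2 differs from compound 1 by butyl in place of hydrogen on an oxygen on an aromatic ring. This step gave a 4.2-fold lower number from compound 1 to compound 2 (0.62 log units; beyond the scatter), so the modification moves the read-out by an amount clearly beyond the usual scatter. Compound 3 shares the lactone framework with compound 1 but the difference between the two cores is not broken down here. In this assay compound 3 sits close to compound 2, and their values lie within the scatter of each other; against compound 1 the value of compound 3 is clearly lower.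

The unmeasured compound 4 `CCCCOc1ccc(C[C@H]2C(=O)OC[C@@H]2Cc2ccccc2)cc1OCCCC` is derived from compound 3 by butyl in place of hydrogen on an oxygen on an aromatic ring. This is the same change as that made from compound 1 to compound 2: the place is the same in both cases, an oxygen on an aromatic ring whose other neighbour is aromatic carbon, and the group entering is butyl in both. Among the compounds with values here, only one earlier example of this change exists, so the expected step for compound 4 rests on a single precedent. Within the data shown here, the step from compound 3 to compound 4 is estimated at a 3.5-fold lower number from compound 3 to compound 4 (0.54 log units; beyond the scatter), which is close to the size seen from compound 1 to compound 2, because a 4.2-fold lower number from compound 1 to compound 2 (0.62 log units; beyond the scatter) is the only measured guide for this change. Since the starting point differs in core, some spread is kept around the estimate. For compound 4 the expected value in this assay is 10000 nM, with a likely range from 4000 nM to 25000 nM.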

Compound 4, half-maximal effective concentration: > 100000 nM
Compound 4 was reported as a limit (the forecaster's own chance of this, stated with the estimate: 5%); at least 10-fold (1.00 log units) between middle value and limit.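

Carried from the core of compound 1 to the core of compound 3, the change of hydroxy to butoxy does not keep its direction in this assay: the same change on two cores in this assay, a 4.2-fold lower number (0.62 log units; beyond the scatter) from compound 1 to compound 2 and an at least 2.8-fold higher number (0.45 log units; beyond the scatter) from compound 3 to compound 4, at least 11-fold (1.07 log units) apart, beyond the scatter of two such steps

The new step reads an at least 2.8-fold higher number from compound 3 to compound 4 (0.45 log units; beyond the scatter), and these two pairs do not show which difference between the cores goes with the opposite direction, nor how large the step on the second core really is. Compound 4 gives > 100000 nM, which is a limit of the assay and not a number: the limit of > 100000 nM in this assay, at which 1 of the 4 values shown sits.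

Open, on these data alone, is how the two cores respond when a methyl or a hexyl chain takes the place of butyl on the same oxygen, which would show whether the opposite directions hold only for butyl. Also open, as far as these compounds go, is whether a chain carrying an amine or a carboxylic acid in place of plain butyl would give a readable value on the core of compound 3, and so a step with two measured ends.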